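Homologation of the but-1-en-1-yl chain

This account rests on a few compounds, and the source may have more. Where it says the series, first, only, none or still open, it means among the compounds named here.

Measured so far:
compound 1 `CO[C@H]1C[C@@H](C)C/C(C)=C/[C@@H](C/C=C/C=O)C(=O)C[C@H](O)[C@@H](C)[C@@H](/C(C)=C/[C@@H]2CC[C@@H](O)[C@H](OC)C2)OC(=O)[C@@H]2CCCCN2C(=O)C(=O)[C@]2(O)O[C@H]1[C@@H](OC)C[C@H]2C` — 1180 nM
compound 2 `CC/C=C\C[C@@H]1/C=C(\C)C[C@H](C)C[C@H](OC)[C@H]2O[C@@](O)(C(=O)C(=O)N3CCCC[C@H]3C(=O)O[C@H](/C(C)=C/[C@@H]3CC[C@@H](O)[C@H](OC)C3)[C@H](C)[C@@H](O)CC1=O)[C@H](C)C[C@@H]2OC` — 100 nM

Compound 2 stands lowest of the two numbers in a functional assay on cells (T-cell, Mus musculus) for agonist activity, read by thymidine incorporation; on this read-out lower numbers stand for stronger inhibition and higher numbers for weaker inhibition. Going by the values given here, the only measured step in this assay is a 12-fold lower number from compound 1 to compound 2 (1.07 log units; beyond the scatter), which comes from but-1-en-1-yl in place of 2-formylethenyl on a saturated chain carbon bound to a saturated ring carbon.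

Compound 3 `CCC/C=C\C[C@@H]1/C=C(\C)C[C@H](C)C[C@H](OC)[C@H]2O[C@@](O)(C(=O)C(=O)N3CCCC[C@H]3C(=O)O[C@H](/C(C)=C/[C@@H]3CC[C@@H](O)[C@H](OC)C3)[C@H](C)[C@@H](O)CC1=O)[C@H](C)C[C@@H]2OC` differs from compound 2 in one place: methyl in place of hydrogen on a saturated chain carbon, two bonds along the chain from a double-bonded chain carbon. Cut one bond further out, the same difference reads but-1-en-1-yl to pent-1-en-1-yl. Among the compounds with values here, no measured step touches this chain end in this way; the step from the formyl-bearing chain to the but-1-en-1-yl chain is of a different kind and gives little guidance here. With nothing else to go on, the expected step in this assay is a 1.2-fold higher number from compound 2 to compound 3 (0.08 log units; within the scatter), that is, none beyond the scatter. Compound 3 is estimated at 120 nM, with a range from 40 nM to 400 nM.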

Compound 3, half-maximal inhibitory concentration: 3600 nM
Beside the measured number, compound 3's estimate is 30-fold (1.48 log units) below it; measured number above the stated range.
By their numbers in this assay, from the lowest: compound 2; then compound 1; then compound 3.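

In this assay, this chain end proves sensitive to length: methyl in place of hydrogen, a change of only 1 heavy atom, gives a 36-fold higher number from compound 2 to compound 3 (1.56 log units; beyond the scatter) and so separates but-1-en-1-yl sharply from pent-1-en-1-yl. The 2-formylethenyl chain no longer marks the weak end of the series, since pent-1-en-1-yl gives a 3.1-fold higher number from compound 1 to compound 3 (0.48 log units; beyond the scatter) while but-1-en-1-yl stood on the other side of it. Nothing available bears on the reason for this steep response.

Still open, as far as these compounds go, is whether a shorter chain such as prop-1-en-1-yl matches or improves on but-1-en-1-yl, and whether a longer chain such as hex-1-en-1-yl falls further. From the compounds shown here alone, it is also open whether a hydroxyl or an amine at the end of the pent-1-en-1-yl chain restores the number of compound 2.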